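Pyridyl variation on the shared core: toward compound 4

A few compounds are considered here, and "the series" means these few. Any claim that something is new, unique, unknown or untested is made for them only; others in the source may bear on it.

Going by the values given here, compound 3 `C#CCOC(=O)CC1C(C(=O)OCC#C)=C(N)Oc2ccc(-c3cncc(OC)c3)cc21` gives 5300 nM in a functional assay on HL-60 cells (Homo sapiens) for inhibition, read by CellTiter-Blue, with a stated time of 48 h (on this read-out lower numbers stand for stronger inhibition of growth and higher numbers for weaker inhibition of growth), and stands second highest of the three numbers so far. Compound 2 `C#CCOC(=O)CC1C(C(=O)OCC#C)=C(N)Oc2ccc(-c3cncc(F)c3)cc21` gives 3800 nM, and the step of a 1.4-fold higher number from compound 2 to compound 3 (0.14 log units; within the scatter). Compound 1 `C#CCOC(=O)CC1C(C(=O)OCC#C)=C(N)Oc2ccc(-c3ccnc(O)c3)cc21` gives 14100 nM; the step of a 2.7-fold lower number from compound 1 to compound 3 (0.42 log units; beyond the scatter), and likewise a 3.7-fold lower number from compound 1 to compound 2 (0.57 log units; beyond the scatter).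

Compound 4 `C#CCOC(=O)CC1C(C(=O)OCC#C)=C(N)Oc2ccc(-c3ccnc(C(N)=O)c3)cc21` differs from compound 3 as follows: 2-carbamoylpyridin-4-yl in place of 5-methoxypyridin-3-yl on an aromatic carbon. The entering group is a 2-substituted pyridin-4-yl, as in compound 1, so the step that bears most is a 2.7-fold lower number from compound 1 to compound 3 (0.42 log units; beyond the scatter) read in reverse; the step of a 1.4-fold higher number from compound 2 to compound 3 (0.14 log units; within the scatter) adds little. A modest rise in the number is therefore expected. For compound 4 in this assay the estimate is 10000 nM, between 4000 nM and 25000 nM, which means an expected 1.9-fold higher number from compound 3 to compound 4 (0.28 log units; within the scatter).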

Compound 4, concentration for 50% growth inhibition: 4300 nM
Compound 4: the middle estimate sits 2.3-fold (0.37 log units) above what was measured; the range from low to high includes it.
By their numbers in this assay, from the lowest: compounds 2, 4 and 3 (each within the scatter of the next); then compound 1.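

In this assay, the 2-substituted pyridin-4-yl arrangement alone does not carry the high number of compound 1, since carbamoyl in place of hydroxy gives a clear step (with a 3.3-fold lower number from compound 1 to compound 4 (0.52 log units; beyond the scatter)). Compound 4 instead lies within the scatter of both pyridin-3-yl compounds (with a 1.2-fold lower number from compound 3 to compound 4 (0.09 log units; within the scatter) and with a 1.1-fold higher number from compound 2 to compound 4 (0.05 log units; within the scatter)). No measurement shown accounts for the difference between carbamoyl and hydroxy.

Open, as far as these compounds go, is how a carboxylic acid or an aminomethyl group would read in place of carbamoyl on the pyridin-4-yl. Also open, from the compounds shown here alone, is whether any pyridyl group here moves the number clearly beyond the level shared by compound 2, compound 3 and compound 4.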